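A few compounds are considered here, and "the series" means these few. Any claim that something is new, unique, unknown or untested is made for them only; others in the source may bear on it.

Working notes on the coumarin-ether amine series, here around compound 1 `C#CCN(CCCOc1ccc2ccc(=O)oc2c1)Cc1ccccc1`. In an ADME assay on isolated protein for inhibition of Amine oxidase [flavin-containing] A (Homo sapiens), read by fluorescence and Amplex Red, with stated times of 15 min and 20 min (on this read-out lower numbers stand for stronger inhibition and higher numbers for weaker inhibition), compound 1 gives 38600 nM, the second highest of the three numbers recorded so far. Its nearest neighbour is compound 3 `C#CCN(CCCCOc1ccc2ccc(=O)oc2c1)Cc1ccc(F)c(F)c1`, which in this assay gives 93200 nM, and furthest from it stands compound 2 `C#CCN(C)CCCCOc1ccc2ccc(=O)oc2c1`, which gives 3280 nM. For the measured compounds named here, the one single-point step so far measured, a 28-fold higher number from compound 2 to compound 3 (1.45 log units; beyond the scatter), concerns the group carried on the saturated chain carbon bound to the amine nitrogen and not a substituent on the aromatic ring of that group.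

The next compound, compound 4 `C#CCN(CCCOc1ccc2ccc(=O)oc2c1)Cc1cccc(OC)c1`, differs from compound 1 by methoxy in place of hydrogen on an aromatic carbon. Going by the values given here, no measured pair changes a substituent on this aromatic ring, so the step from compound 2 to compound 3 bears on it only indirectly, as the sole indication of how sensitive this assay is to changes in that region. Among the compounds with values here, with no direct precedent, a step within the scatter is expected, in either direction, with wide uncertainty.

Estimate: compound 4 is expected to give 35000 nM, between 12000 nM and 100000 nM, which would mean a step of a 1.1-fold lower number from compound 1 to compound 4 (0.04 log units; within the scatter).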

Compound 4, half-maximal inhibitory concentration: 22700 nM
Compound 4: the middle estimate sits 1.5-fold (0.19 log units) above what was measured, and the stated range covers the measured number.
By their numbers in this assay, from the lowest: compound 2; then compounds 4 and 1 (each within the scatter of the next); then compound 3.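

In this assay, for the compounds shown here, the first reading of a change on the aromatic ring of the benzyl group itself, a 1.7-fold lower number from compound 1 to compound 4 (0.23 log units; within the scatter), lies within the scatter, so 3-methoxybenzyl cannot be told apart from benzyl at this position, meta to a large group. The sensitivity seen in a 28-fold higher number from compound 2 to compound 3 (1.45 log units; beyond the scatter), which concerns the group on the saturated chain carbon bound to the amine nitrogen, therefore does not appear with this ring substitution. No measurement in hand accounts for this reading.

Still open, on these data alone, is whether a hydroxyl or benzyloxy group on this aromatic carbon would give a step beyond the scatter. The compounds shown also do not tell whether methoxy would read the same way with a different chain joining the amine to the shared core.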